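Removing one methyl from a potent growth inhibitor

The compounds below may be only part of what the source reports. "The series", "measured", "known", "first", "only" and "open" are said of these compounds alone.

Compound 1 `Cc1ccnc2nc(-c3ccc(F)cc3)cc(O)c12` gives 3550 nM
Compound 2 `COc1cccc(-c2cc(O)c3cc(C)cnc3n2)c1` gives < 10 nM as a limit
Compound 3 `Cc1cnc2nc(-c3ccc(F)cc3)cc(O)c2c1` gives 3020 nM

All three values come from a functional assay on MDA-N cells (Homo sapiens) (a higher number here means a weaker inhibitor of growth, a lower number a stronger inhibitor of growth), and no two of these compounds differ in only one place. Compound 2 alone sits at the limit of < 10 nM in this assay, at which 1 of the 3 values shown sits, and its value is a limit of the assay, not a number.

Compound 4 `COc1cccc(-c2cc(O)c3cccnc3n2)c1` is compound 2 with one small change (hydrogen in place of methyl on an aromatic carbon) in which hydrogen takes the place of methyl on an aromatic carbon. Within the data shown here, no measured pair shows what this methyl alone is worth in this assay so the size of the step is a judgement. Compound 4 keeps everything else of compound 2, which shows < 10 nM as a limit, so a moderate weakening is expected rather than a collapse. The expected shift is an at least 4.0-fold higher number from compound 2 to compound 4 (0.60 log units; beyond the scatter) and it remains an estimate. For compound 4 the estimate is 40 nM with a range from 10 nM to 300 nM expected.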

Compound 4, concentration for 50% growth inhibition: < 10 nM
Compound 4 gave a limit, no number; the forecaster's own chance of this, stated with the estimate: 25%; middle value at least 4.0-fold (0.60 log units) away from the limit.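

In this assay, among these compounds, compound 2 and compound 4 both give a limit, not a number, so no step between them can be read: the limit of < 10 nM in this assay, at which 2 of the 4 values shown sit. Going by these compounds, what the methyl on the aromatic carbon alone is worth in this assay stays open, and so does the exact potency of either compound.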